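A few compounds are considered here, and "the series" means these few. Any claim that something is new, unique, unknown or untested is made for them only; others in the source may bear on it.

Three compounds share a core and differ only in the aryl ring on the carbonyl carbon. Compound 1 `COc1cc(-c2cc(/C=C/C(=O)c3ccc(N)cc3)[nH]n2)cc(OC)c1OC` gives 94% in a functional assay on PC-3 cells (Homo sapiens) for cytotoxicity, read by sulforhodamine B assay, with a stated time of 48 h, tested at 0.1 uM; on this read-out lower numbers stand for a stronger effect and higher numbers for a weaker effect at the one concentration tested; compound 2 `COc1cc(-c2cc(/C=C/C(=O)c3ccc(Cl)c(Cl)c3)[nH]n2)cc(OC)c1OC` gives 100%; compound 3 `COc1ccc(C(=O)/C=C/c2cc(-c3cc(OC)c(OC)c(OC)c3)n[nH]2)cc1OC` gives 95%. Compound 3 stands second highest of the three numbers, with compound 1 nearest and compound 2 furthest, and every gap between them lies within the scatter: a number 6 percentage points higher from compound 1 to compound 2 (within the scatter), a number 1 percentage points higher from compound 1 to compound 3 (within the scatter) and a number 5 percentage points lower from compound 2 to compound 3 (within the scatter). Compound 4 `COc1ccc(C(=O)/C=C/c2cc(-c3cc(OC)c(OC)c(OC)c3)n[nH]2)cc1` is not yet measured. It differs from compound 3 in one place: hydrogen in place of methoxy on an aromatic carbon. The measured steps that bear on this change are those that vary the same aryl ring, namely the step from compound 1 to compound 3 and the step from compound 2 to compound 3, and both stayed within the scatter although they exchanged whole substituent patterns. Removing a single methoxy is a smaller change, so no step beyond the scatter is expected in this assay. Compound 4 is therefore estimated at 95%, within 85% to 103%, which means an expected step of no change at the digits printed from compound 3 to compound 4 (within the scatter).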

Compound 4, a percentage reported as activity, at one concentration (the size of the read-out at that concentration, not a potency): 95%
The estimate for compound 4 equals the measured number at the digits printed; measured number inside the range.
By their numbers in this assay, from the lowest: compounds 1, 3, 4 and 2 (each within the scatter of the next).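

Taking away the methoxy ortho to a methoxy group leaves the number in this assay unmoved (no change at the digits printed from compound 3 to compound 4 (within the scatter)), so this position tolerates the loss of that single group at the one concentration tested. The earlier steps shown here exchanged whole substituent patterns, whereas the new steps also show that a change at one aromatic carbon makes no readable difference: methoxy in place of amino stays within the scatter (a number 1 percentage points higher from compound 1 to compound 4 (within the scatter)), and the 4-methoxyphenyl ring cannot be told apart from the 3,4-dichlorophenyl ring (a number 5 percentage points lower from compound 2 to compound 4 (within the scatter)). Nothing at hand accounts for this flatness.

Since no step here leaves the scatter, the compounds shown do not settle whether this aryl ring matters at all in this read-out. A hydroxy group, a carboxylic acid or a longer ethoxy chain at this place remains an open case.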